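Permeability notes on compounds 1 to 4

This account rests on a few compounds, and the source may have more. Where it says the series, first, only, none or still open, it means among the compounds named here.

Measured compounds:
compound 1, `Cc1oc(-c2ccccc2Cl)nc1CN1CCC(C(=O)NCCCN2C[C@H](C)C[C@H](C)C2)CC1`, gives 352 10^-6 cm/s
compound 2, `CC[C@@H]1C[C@H](CC)CN(CCCNC(=O)C2CCN(Cc3nc(-c4c(F)cccc4F)oc3C)CC2)C1`, gives 130 10^-6 cm/s
compound 3, `Cc1ccccc1-c1nc(CN2CCC(C(=O)NCCCN3CC4CCCC(C4)C3)CC2)c(C)o1`, gives 331 10^-6 cm/s

In a physicochemical assay for permeability, using PAMPA (a lower number here means that the compound crosses the layer more slowly, a higher number that the compound crosses the layer faster), compound 1 stands highest of the three numbers. Compound 3 sits within the scatter of compound 1, so no order between them is claimed; compound 2 lies beyond the scatter, lower. Compound 4, `Cc1cccc(F)c1-c1nc(CN2CCC(C(=O)NCCCN3C[C@H](C)C[C@H](C)C3)CC2)c(C)o1`, is not yet measured. It differs from compound 1 in one place: 2-fluoro-6-methylphenyl in place of 2-chlorophenyl on an aromatic carbon. For the measured compounds named here, no pair of measured compounds isolates this change, and compounds 2 and 3 differ from compound 1 in more than one place, so the change is judged on its own. Compound 4 is expected to stay near compound 1, with no step beyond the scatter, a 1.2-fold lower number from compound 1 to compound 4 (0.07 log units; within the scatter). Compound 4 is estimated at 300 10^-6 cm/s, with a range from 150 10^-6 cm/s to 550 10^-6 cm/s.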

Compound 4, apparent permeability: 234 10^-6 cm/s
Estimate against measurement, compound 4: 1.3-fold (0.11 log units) above; the range from low to high includes it.
By their numbers in this assay, from the lowest: compounds 2, 4, 3 and 1 (each within the scatter of the next, the first and the last beyond it).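

For the compounds shown here, this is the first one-place comparison at this aromatic carbon of the five-membered ring: in this assay, 2-fluoro-6-methylphenyl in place of 2-chlorophenyl gives a 1.5-fold lower number from compound 1 to compound 4 (0.18 log units; within the scatter) and so stays within the scatter. At this position, then, the two aryl groups are not told apart, even though the entering group adds a second substituent on the phenyl ring. No available measurement bears on the reason for this result. Still open, as far as these compounds go, is how a pyridine ring or a carboxylic acid at this carbon would read in this assay on the core of compound 1.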